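A methoxy for a methyl in compound 4

This account rests on a few compounds, and the source may have more. Where it says the series, first, only, none or still open, it means among the compounds named here.

In a functional assay on BT-483 cells (Homo sapiens) for cytotoxicity, read by MTT assay, with a stated time of 24 h (a lower number here means a stronger inhibitor, a higher number a weaker inhibitor), the measured compounds gave these values:
compound 1 `CCNc1cc(-c2ccc(NC(=O)Nc3ccc(C)cc3)cc2C)ccn1` gives 22000 nM
compound 2 `CCNc1cc(-c2ccc(NC(=O)Nc3ccc(OC)cc3)cc2C)ccn1` gives 25800 nM
compound 3 `CCNc1cc(-c2ccc(NC(=O)Nc3c(C)cccc3C)cc2C)ccn1` gives > 30000 nM as a limit of the assay, not a number

Compound 2, at 25800 nM in this assay, cannot be told apart from its nearest neighbour (a 1.2-fold higher number from compound 1 to compound 2 (0.07 log units; within the scatter)). The third compound offers no number to compare with, only its limit.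

The next compound, compound 4 `CCNc1cc(-c2ccc(NC(=O)Nc3ccc(OC)cc3)cc2OC)ccn1`, differs from compound 2 at a single place (methoxy in place of methyl on an aromatic carbon). There a methoxy replaces a methyl on an aromatic carbon, ortho to a 2-(ethylamino)pyridin-4-yl group.

One measured step makes the same swap of methyl for methoxy on an aromatic carbon, though not at the same place (a 1.2-fold higher number from compound 1 to compound 2 (0.07 log units; within the scatter)). That step lies within the scatter, so it gives no reason to expect a real shift. The steps to compound 3 change the group on an amide-type nitrogen instead, so they do not bear on this swap.

No step beyond the scatter is therefore expected in this assay, and no direction can be favoured. The expected change is small (a 1.0-fold lower number from compound 2 to compound 4 (0.01 log units; within the scatter)). Compound 4 is estimated at 25000 nM, with an expected range from 13000 nM to 48000 nM.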

Compound 4, half-maximal inhibitory concentration: > 30000 nM
Compound 4 was reported as a limit; the forecaster's own chance of this, stated with the estimate: 35%; middle value at least 1.2-fold (0.07 log units) from the limit.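

In this assay compound 4 gives > 30000 nM, which is a limit of the assay and not a number. Compound 1, compound 2 and compound 3 all carry a methyl ortho to the 2-(ethylamino)pyridin-4-yl group, which makes compound 4 the only compound shown with a different group at this position, and the swap to methoxy yields only a floor, one that does not go beyond the usual scatter: an at least 1.1-fold higher number from compound 2 to compound 4 (0.06 log units; that floor lies within the scatter). On these data alone, the methoxy therefore brings no lower number into view at this position, but the true size of the change stays unknown, and compound 4 now shares a reading with compound 3: the limit of > 30000 nM in this assay, at which 2 of the 4 values shown sit.

With only methyl and methoxy shown here, it remains open how this position would respond to an amine, a fluorine atom or a longer chain such as ethyl. As far as these compounds go, it also remains open whether any group at this position could give a clearly lower number in this assay than the methyl of compound 2, or whether the methoxy truly raises the number.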